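The source may report more compounds than this note shows. Statements on the series, on what has been measured and on what is new or still open speak of the compounds shown alone.

Of the compounds shown here, three built on the shared core have been measured in a functional assay on MCF7 cells (Homo sapiens) for inhibition, read by MTT assay, with a stated time of 48 h; a lower number here means a stronger inhibitor, a higher number a weaker inhibitor. Compound 1 `COc1ccc(/C=N/NC(=O)CSc2nnc(-c3ccncc3)n2-c2ccccc2)cc1` gives 23700 nM. Compound 2 `O=C(CSc1nnc(-c2ccncc2)n1-c1ccccc1)N/N=C/c1ccc(O)cc1` reaches only the limit of the assay, > 50000 nM, and so supplies no number. Compound 3 `O=C(CSc1nnc(-c2ccncc2)n1-c1ccccc1)N/N=C/c1ccc(Br)cc1` gives 7040 nM, the lowest of the two numbers shown, and the step of a 3.4-fold lower number from compound 1 to compound 3 (0.53 log units; beyond the scatter) lies beyond the scatter. The other step that ends at compound 3, an at least 7.1-fold lower number from compound 2 to compound 3 (0.85 log units; beyond the scatter), rests on the limit of > 50000 nM in this assay, at which 1 of the 3 values shown sits, and therefore gives only a lower bound for its size.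

Compound 4 `O=C(CSc1nnc(-c2ccncc2)n1-c1ccccc1)N/N=C/c1ccc(Cl)cc1` has not yet been measured. It differs from compound 3 in one place: chloro in place of bromo on an aromatic carbon. Going by the values given here, none of the measured steps exchanges one halogen for another; both steps that end at compound 3 replace an oxygen-bearing group with bromo, and both lowered the number. That shows the direction seen so far when bromo enters, but says nothing about the size of a bromo-to-chloro swap. The expected step is a 1.3-fold higher number from compound 3 to compound 4 (0.11 log units; within the scatter), and it is estimated to stay within the scatter. The estimate for compound 4 in this assay is 9000 nM, with a range from 4000 nM to 25000 nM.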

Compound 4, half-maximal inhibitory concentration: 9930 nM
Compound 4: the middle estimate sits 1.1-fold (0.04 log units) below what was measured; the measured number falls inside the stated range.
By their numbers in this assay, from the lowest: compounds 3 and 4 (each within the scatter of the next); then compound 1. At a limit, above all of these: compound 2.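

In this assay, the step of a 1.4-fold higher number from compound 3 to compound 4 (0.15 log units; within the scatter) is the only exchange of one halogen for another shown, and it lies within the scatter, so going from 4-bromophenyl to 4-chlorophenyl at this position, para to a large group, makes no readable difference. The lower number seen when bromo replaced methoxy is therefore not unique to bromo, since chloro in the same place also gives a step beyond the scatter, a 2.4-fold lower number from compound 1 to compound 4 (0.38 log units; beyond the scatter), and compounds 3 and 4 cannot be told apart in this assay. Compound 2 stands at a limit, so the step of an at least 5.0-fold lower number from compound 2 to compound 4 (0.70 log units; beyond the scatter) gives only a lower bound for its size: the limit of > 50000 nM in this assay, at which 1 of the 4 values shown sits.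

The compounds shown leave open how far this tolerance for halogens extends, as fluoro and iodo lie outside the set, and whether a group without a halogen, such as methyl, nitrile or an amine, would fall with compounds 3 and 4 or with compound 1. They also leave open the true size of the gap to compound 2, whose limit supplies no number.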